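The compounds below may be only part of what the source reports. "The series", "measured", "known", "first", "only" and "open" are said of these compounds alone.

Series notes. Compound 1 `CC(=O)Nc1ccc2oc(-c3ccccc3)cc(=O)c2c1` in an ADME assay on MT4 cells (Homo sapiens) for cytotoxicity, read by MTT assay, with a stated time of 4 days (a lower number here means that less compound is tolerated, a higher number that more compound is tolerated), gives 184000 nM. Compound 2 `COc1c(-c2ccccc2)oc2ccc(NC(C)=O)cc2c1=O` gives 200000 nM, and the step of a 1.1-fold higher number from compound 1 to compound 2 (0.04 log units; within the scatter) carries the change (methoxy in place of hydrogen on an aromatic carbon). Compound 3 `COc1c(-c2ccccc2)oc2ccc(N)cc2c1=O` gives 126000 nM, reached by the step of a 1.6-fold lower number from compound 2 to compound 3 (0.20 log units; within the scatter). Compound 3 sits no further from compound 1 or compound 2 than the scatter allows, so the three measured numbers are read as indistinguishable. Compound 4 `COc1cccc(-c2oc3ccc(N)cc3c(=O)c2OC)c1` is not yet measured. From compound 3 it differs by methoxy in place of hydrogen on an aromatic carbon. How the cores of compound 1 and compound 3 differ is not broken down here. The change from compound 3 to compound 4 is the same kind of change as from compound 1 to compound 2, not the same: the earlier methoxy entered a six-membered aromatic ring with one oxygen in a fused system, ortho to a phenyl group and two atoms from the ring oxygen, whereas the new one enters a six-membered ring of carbon only, meta to a large group. Because the earlier step of a 1.1-fold higher number from compound 1 to compound 2 (0.04 log units; within the scatter) stayed within the scatter, the step for compound 4 is expected to be a 1.0-fold higher number from compound 3 to compound 4 (0.01 log units; within the scatter). Compound 4 is estimated at 130000 nM, between 65000 nM and 260000 nM.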

Compound 4, half-maximal cytotoxic concentration: 251000 nM
Compound 4: the middle estimate sits 1.9-fold (0.29 log units) below what was measured; low and high end bracket the measured number.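

In this assay, the step of a 2.0-fold higher number from compound 3 to compound 4 (0.30 log units; within the scatter) comes with methoxy in place of hydrogen on an aromatic carbon, here on the six-membered aromatic ring of carbon only. Set beside the same kind of change on the core of compound 1, the two steps cannot be told apart: the same change on two cores in this assay, a 1.1-fold higher number (0.04 log units; within the scatter) from compound 1 to compound 2 and a 2.0-fold higher number (0.30 log units; within the scatter) from compound 3 to compound 4, 1.8-fold (0.26 log units) apart, within the scatter of two such steps. Going by these compounds alone, on these two cores, the change therefore leaves the number within the scatter, but the evidence is only one pair per core with the methoxy in a different ring each time, so it shows agreement between two steps and not a rule that holds on other cores or in other places.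

The compounds shown leave open whether a different group on the same aromatic carbon, such as a hydroxyl, an amine or a longer alkoxy chain, would also stay within the scatter. They also leave open whether methoxy on the carbon-only ring behaves the same way when the amine of the core is acetylated, as in compound 2.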